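The source may report more compounds than this note shows. Statements on the series, on what has been measured and on what is new or still open speak of the compounds shown alone.

Among the compounds with values here, compound 2 `Cc1nc(S(C)(=O)=O)ccc1Oc1ncnc(OC2CCN(C(=O)C(C)(C)F)CC2)c1F` gives 74% in a functional assay on isolated protein for inhibition of Glucose-dependent insulinotropic receptor (Rattus norvegicus), read by HTRF and cAMP accumulation (a lower number here means a smaller maximal response, a higher number a larger maximal response), the lower of the two numbers measured so far, while compound 1 `Cc1nc(S(C)(=O)=O)ccc1Oc1ncnc(OC2CCN(C(=O)OC(C)(C)C#N)CC2)c1F` gives 97%. Within the data shown here, the one measured step, a number 23 percentage points lower from compound 1 to compound 2 (beyond the scatter), concerns a different exchange on a carbonyl carbon and shows that such exchanges can move the maximal response by a modest amount. Compound 3 `Cc1nc(S(C)(=O)=O)ccc1Oc1ncnc(OC2CCN(C(=O)c3ncc(Cl)cn3)CC2)c1F` differs from compound 2 by 5-chloropyrimidin-2-yl in place of 1-fluoro-1-methylethyl on a carbonyl carbon. Among the measured compounds shown here, no measured step covers this exchange, so its direction is open. Compound 3 is therefore expected to give about 85%, between 65% and 100%. This estimate means a step of a number 11 percentage points higher from compound 2 to compound 3 (beyond the scatter).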

Compound 3, largest response reached (reported as efficacy), in percent of the reference or control that the assay uses: 77%
For compound 3 the middle estimate is 8 percentage points above the measured one; measured number inside the range.
By their numbers in this assay, from the lowest: compounds 2 and 3 (each within the scatter of the next); then compound 1.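

In this assay, 5-chloropyrimidin-2-yl in place of 1-fluoro-1-methylethyl on the carbonyl carbon brings a number 3 percentage points higher from compound 2 to compound 3 (within the scatter), so this position accepts an aromatic ring and an open chain with no distinction in maximal response. The exchange from 1-cyano-1-methylethoxy brings a number 20 percentage points lower from compound 1 to compound 3 (beyond the scatter), which leaves compound 1 apart from both compound 2 and compound 3. Nothing available explains this grouping. From the compounds shown here alone, whether an amine or a plain phenyl ring on this carbonyl carbon would fall with compound 1 or with the other two remains open.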